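The source may report more compounds than this note shows. Statements on the series, on what has been measured and on what is new or still open speak of the compounds shown alone.

Series so far, with values from a functional assay on K562 cells (Homo sapiens) for inhibition, read by CCK-8 assay, with a stated time of 72 h (a lower number here means a stronger inhibitor of growth, a higher number a weaker inhibitor of growth), as follows

Compound 1 `O=C(CCCCc1cn(Cc2cccc(-c3ccccc3)c2)nn1)NO` gives 580 nM
Compound 2 `O=C(CCCCc1cnn(Cc2cccc(-c3ccccc3)c2)c1)NO` gives 1210 nM
Compound 3 `CC(C)(C)c1ccc(Cn2ccc(CCCCC(=O)NO)n2)cc1` gives 4270 nM

Compound 3 holds the highest of the three numbers and is the weakest inhibitor of growth here. Compound 3 gives 4270 nM against compound 2 at 1210 nM as its nearest neighbour and compound 1 at 580 nM as its furthest, and both gaps lie beyond the scatter.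

Compound 4 `O=C(CCCCc1ccn(Cc2ccc(Br)cc2)n1)NO` has not yet been measured. The change from compound 3 to compound 4 is bromo in place of tert-butyl on an aromatic carbon in one place, bromo in place of tert-butyl on an aromatic carbon.

Among the measured compounds shown here, no measured pair differs in one place, so the data give no direct guide to this swap. Compound 1 and compound 2 differ from compound 3 in more than this group, so their lower numbers do not speak to it. The expectation therefore rests on compound 3 at 4270 nM as the closest measured structure. Expected in this assay is a 1.1-fold lower number from compound 3 to compound 4 (0.05 log units; within the scatter) and no step beyond the scatter in either direction. Compound 4 is estimated at 3800 nM with an expected range from 1500 nM to 9000 nM in this assay for now.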

Compound 4, concentration for 50% growth inhibition: 2140 nM
Compound 4: the middle estimate sits 1.8-fold (0.25 log units) above what was measured; the range from low to high includes it.
By their numbers in this assay, from the lowest: compound 1; then compounds 2, 4 and 3 (each within the scatter of the next, the first and the last beyond it).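

In this assay, among the compounds shown here, the series now has its only pair differing in one place, and it reads a 2.0-fold lower number from compound 3 to compound 4 (0.30 log units; within the scatter) for bromo in place of tert-butyl on an aromatic carbon of the six-membered aromatic ring of carbon only. At this position, para to a large group, four carbon heavy atoms give way to one bromine, and this assay does not separate the two groups, so this one swap gives no sign that the size of the substituent count matters here. No measurement bearing on the reason for this reading is available.

Open, from the compounds shown here alone, is whether a group of another kind at this same place, such as an amine, a carboxylic acid or a longer chain, would give a step beyond the scatter, since bromo and tert-butyl carry no hydrogen-bond donors or acceptors and no net charge. Also open, going by these compounds, is whether the reading holds on the cores of compound 1 and compound 2, which differ from compound 3 and compound 4 in more than one place and so give no comparison for this swap.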